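The source may report more compounds than this note shows. Statements on the series, on what has been measured and on what is new or still open speak of the compounds shown alone.

Compound 2 `COc1cc(-c2ccnc3cc(-c4ccccc4)nn23)cc(OC)c1OC` carries a phenyl on the shared core, and in a functional assay on MCF7 cells (Homo sapiens) for inhibition, read by CCK-8 assay, with a stated time of 48 h (on this read-out higher numbers stand for weaker inhibition and lower numbers for stronger inhibition), compound 2 gives 254 nM, the lowest of the two numbers recorded, with compound 3 `COc1cc(-c2ccnc3cc(-c4cn(C(=O)OC(C)(C)C)c5ccccc45)nn23)cc(OC)c1OC` giving 268 nM, which lies within the scatter of compound 2. Compound 1 `COc1cc(-c2cc3nccc(-c4cc(OC)c(OC)c(OC)c4)n3n2)cc(OC)c1OC` returns only a limit in this assay, > 10000 nM. Compound 4 `COc1ccc(-c2cc3nccc(-c4cc(OC)c(OC)c(OC)c4)n3n2)cc1N` has not yet been measured; it differs from compound 2 by 3-amino-4-methoxyphenyl in place of phenyl on an aromatic carbon. For the measured compounds named here, no measured pair shows the effect of such a change, so the expected step is modest. Compound 4 is estimated at 150 nM, between 40 nM and 800 nM, which would be a step of a 1.7-fold lower number from compound 2 to compound 4 (0.23 log units; within the scatter), only slightly beyond the scatter toward stronger inhibition if at all.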

Compound 4, half-maximal inhibitory concentration: 27 nM
Compound 4: the middle estimate sits 5.6-fold (0.74 log units) above what was measured; measured number outside the range, below it.
By their numbers in this assay, from the lowest: compound 4; then compounds 2 and 3 (each within the scatter of the next). At a limit, above all of these: compound 1.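

In this assay, 3-amino-4-methoxyphenyl in place of phenyl on this aromatic carbon gives a 9.4-fold lower number from compound 2 to compound 4 (0.97 log units; beyond the scatter). For the compounds shown here, no earlier pair could show this: the position responds clearly to what the phenyl ring carries, and the step lies beyond the scatter. From the compounds shown here alone, the amine and the methoxy group enter together, so the share of each stays open, as does the outcome with a hydroxyl or a fluorine in place of the amine. Steps to compound 1 cannot be read, as its value is only a limit: the limit of > 10000 nM in this assay, at which 1 of the 4 values shown sits.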